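Chloro Gives Way to Methoxy: Compound 3 to Compound 4

This account rests on a few compounds, and the source may have more. Where it says the series, first, only, none or still open, it means among the compounds named here.

Measured so far:
Compound 1, `COCOc1cc(/C=C/C(=O)OCC(=O)NCc2ccco2)ccc1OCc1ccccc1`: 300 nM
Compound 2, `CCOc1ccc(COc2c(OC)cc(/C=C/C(=O)OCC(=O)Nc3ccccc3)cc2OC)cc1`: a limit, > 200000 nM
Compound 3, `O=C(COC(=O)/C=C/c1ccc(O)c(O)c1)Nc1ccc(Cl)cc1`: 99400 nM

In a functional assay on K562 cells (Homo sapiens) for cytotoxicity, read by MTT assay, with a stated time of 72 h (on this read-out lower numbers stand for stronger inhibition and higher numbers for weaker inhibition), compound 1 gives 300 nM. Compound 2 reaches only a limit of the assay, > 200000 nM, as noted in the limit of > 200000 nM in this assay, at which 1 of the 3 values shown sits. Compound 3 gives 99400 nM, the higher of the two numbers and well beyond the scatter from compound 1. Compound 4, `COc1ccc(NC(=O)COC(=O)/C=C/c2ccc(O)c(O)c2)cc1`, differs from compound 3 in one place: methoxy in place of chloro on an aromatic carbon. Among the measured compounds shown here, no measured pair shows this change, so its size is open; the expectation is a step of no more than the scatter, in no definite direction. Compound 4 is expected to give about 110000 nM, between 35000 nM and 350000 nM. That estimate means an expected step of a 1.1-fold higher number from compound 3 to compound 4 (0.04 log units; within the scatter) of essentially none.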

Compound 4, half-maximal inhibitory concentration: 79100 nM
Beside the measured number, compound 4's estimate is 1.4-fold (0.14 log units) above it; the range from low to high includes it.
By their numbers in this assay, from the lowest: compound 1; then compounds 4 and 3 (each within the scatter of the next). At a limit, above all of these: compound 2.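

In this assay, methoxy in place of chloro, para to a large group, gives a 1.3-fold lower number from compound 3 to compound 4 (0.10 log units; within the scatter) and so provides the only measured step among these compounds. At this position, the change from 4-chlorophenyl to 4-methoxyphenyl adds one hydrogen-bond acceptor, yet the number stays within the scatter. Nothing measured here bears on why the step is this size. The compounds shown leave open whether a different group at this position, such as an amine or a carboxylic acid, would move the number beyond the scatter.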